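Lengthening the hexyloxy chain of compound 3

This account rests on a few compounds, and the source may have more. Where it says the series, first, only, none or still open, it means among the compounds named here.

Measured so far in an assay on microsomes from liver for inhibition of sterol O-acyltransferase 1 (Rattus norvegicus); on this read-out lower numbers stand for stronger inhibition and higher numbers for weaker inhibition: compound 1 `CCCCCCCNc1cc(-c2ccccc2)c(-c2ccccc2)nn1` gives 55000 nM. Compound 3 `CCCCCCOc1cc(-c2ccccc2)c(-c2ccccc2)nn1` gives 72000 nM. Compound 2 `CCCCCC(=O)Nc1cc(-c2ccccc2)c(-c2ccccc2)nn1` gives only a limit, > 300000 nM.

Compound 3 sits beside compound 1: the step of a 1.3-fold higher number from compound 1 to compound 3 (0.12 log units; within the scatter) is within the scatter, so the two cannot be ordered. Within the data shown here, the steps of an at least 5.4-fold higher number from compound 1 to compound 2 (0.73 log units; beyond the scatter) and an at least 4.1-fold lower number from compound 2 to compound 3 (0.61 log units; beyond the scatter) concern the acylated nitrogen and have no counterpart in the change now considered.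

Compound 4 `CCCCCCCCOc1cc(-c2ccccc2)c(-c2ccccc2)nn1` differs from compound 3 by ethyl in place of hydrogen on a saturated chain carbon, six bonds along the chain from an oxygen on an aromatic ring. Among the measured compounds shown here, no measured step alters chain length alone; the nearest evidence, the within-scatter step from heptylamino to hexyloxy, gives no direction. In this assay no step beyond the scatter is therefore expected for compound 4, estimated at 60000 nM (range 20000 nM to 200000 nM), meaning an expected step of a 1.2-fold lower number from compound 3 to compound 4 (0.08 log units; within the scatter).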

Compound 4, half-maximal inhibitory concentration: 104000 nM
Estimate against measurement, compound 4: 1.7-fold (0.24 log units) below; the measured number falls inside the stated range.
By their numbers in this assay, from the lowest: compounds 1, 3 and 4 (each within the scatter of the next). At a limit, above all of these: compound 2.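

Ethyl in place of hydrogen on this saturated chain carbon is the first step that alters chain length alone, and it stays within the scatter, with a 1.4-fold higher number from compound 3 to compound 4 (0.16 log units; within the scatter). Octyloxy and heptylamino cannot be ordered either, with a 1.9-fold higher number from compound 1 to compound 4 (0.28 log units; within the scatter). Compound 2 gives only a limit, so an at least 2.8-fold lower number from compound 2 to compound 4 (0.46 log units; beyond the scatter) is a bound and not a measured size: the limit of > 300000 nM in this assay, at which 1 of the 4 values shown sits.

From the compounds shown here alone, whether a longer chain such as dodecyloxy takes the number beyond the scatter remains open. Also open, going by these compounds, is what a carboxylic acid or an amine at the end of the chain would do.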